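This account rests on a few compounds, and the source may have more. Where it says the series, first, only, none or still open, it means among the compounds named here.

Compound 1 `COc1cccc(/C=C2\CCC/C(=C\c3ccc(Cl)cc3)C2=O)c1OC`: 18600 nM
Compound 2 `COc1ccc(/C=C2\CCC/C(=C\c3ccccc3Br)C2=O)cc1OC`: 21800 nM

In an ADME assay on NHDF cells (Homo sapiens) for cytotoxicity, read by MTT assay, with a stated time of 72 h (on this read-out higher numbers stand for weaker inhibition and lower numbers for stronger inhibition), compound 2 gives 21800 nM, the highest of the two numbers, while compound 1 gives 18600 nM, a reading within the scatter of compound 2, so the two are not distinguishable on this read-out.

Compound 3 `COc1cc(/C=C2\CCC/C(=C\c3ccc(OC)c(OC)c3)C2=O)ccc1O` differs from compound 2 by the change (4-hydroxy-3-methoxyphenyl in place of 2-bromophenyl on a double-bonded chain carbon bound to a double-bonded ring carbon). For the measured compounds named here, no measured step accompanies this change, and the two numbers at hand give no lead on its direction, so the step from compound 2 to compound 3 is expected to be small, none beyond the scatter, as a 1.1-fold higher number from compound 2 to compound 3 (0.04 log units; within the scatter). Compound 3 is therefore estimated at 24000 nM, within a range from 9000 nM to 65000 nM.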

Compound 3, half-maximal inhibitory concentration: 13700 nM
Compound 3: the middle estimate sits 1.8-fold (0.24 log units) above what was measured; the measured number falls inside the stated range.
By their numbers in this assay, from the lowest: compounds 3, 1 and 2 (each within the scatter of the next).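

In this assay the change to 4-hydroxy-3-methoxyphenyl in place of 2-bromophenyl on a double-bonded chain carbon bound to a double-bonded ring carbon gives a 1.6-fold lower number from compound 2 to compound 3 (0.20 log units; within the scatter) and so stays within the scatter. This first single-place comparison shows that a group carrying a hydrogen-bond donor and hydrogen-bond acceptors can stand here in place of one with neither, without a step beyond the scatter. Nothing at hand offers an explanation for this reading. As far as these compounds go, whether an amine or a carboxylic acid at this place would also stay within the scatter remains open.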